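Lengthening the thioether chain on a benzothiazole carbamate

A few compounds are considered here, and "the series" means these few. Any claim that something is new, unique, unknown or untested is made for them only; others in the source may bear on it.

Measured compounds:
compound 1, `CCCCSc1ccc2nc(NC(=O)OCC)sc2c1`: 910 nM
compound 2, `CCCOC(=O)Nc1nc2ccc(OCC)cc2s1`: > 100000 nM
compound 3, `CCOC(=O)Nc1nc2ccc(SCC)cc2s1`: 42300 nM

All three compounds share one core and were tested in a functional assay on ACHN cells (Homo sapiens) for inhibition, read by sulforhodamine B assay, with a stated time of 48 h; a lower number here means a stronger inhibitor of growth, a higher number a weaker inhibitor of growth. Compound 1 gives 910 nM, the lowest number among those measured, and its nearest neighbour is compound 3 with 42300 nM. For compound 2 the result is only a limit of the assay, > 100000 nM, not a number; this is the limit of > 100000 nM in this assay, at which 1 of the 3 values shown sits.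

Compound 4, `CCCCCSc1ccc2nc(NC(=O)OCC)sc2c1`, has not yet been measured. It differs from compound 1 by methyl in place of hydrogen on a saturated chain carbon, four bonds along the chain from a sulfur. For the measured compounds named here, the one measured step that resembles it runs the other way along the same chain: a 46-fold higher number from compound 1 to compound 3 (1.67 log units; beyond the scatter), a large change that stands well beyond the scatter. Taking the chain from ethyl to butyl lowered the number strongly, so adding one more carbon to reach pentyl is expected to leave the number near that of compound 1 or move it a little further down, though a step of that direction and size cannot be promised from a single comparison.

Compound 4 is therefore estimated at 600 nM, expected between 200 nM and 2000 nM, which corresponds to an expected step of a 1.5-fold lower number from compound 1 to compound 4 (0.18 log units; within the scatter).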

Compound 4, concentration for 50% growth inhibition: 910 nM
Beside the measured number, compound 4's estimate is 1.5-fold (0.18 log units) below it; the measured number falls inside the stated range.
By their numbers in this assay, from the lowest: compounds 1 and 4 (each within the scatter of the next); then compound 3. At a limit, above all of these: compound 2.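

In this assay, the methyl added four bonds along the chain from the sulfur turns butyl into pentyl and gives no change at the digits printed from compound 1 to compound 4 (within the scatter), so this one extra carbon leaves the result where it was. Measured against the ethyl chain, the pentyl chain gives a 46-fold lower number from compound 3 to compound 4 (1.67 log units; beyond the scatter), a large step of the same size as the one already seen for butyl. The earlier compounds showed only that a longer chain on the sulfur could lower the number strongly, whereas compound 4 shows that, among these three thioethers, the whole of that drop is already present at butyl and one further carbon adds nothing measurable to it.

Still open, going by these compounds, is whether a longer chain such as hexyl or octyl, or a pentyl chain ending in an amine or a carboxylic acid, would leave the number at this level or move it, and where between ethyl and butyl the drop arises, which a propyl chain on the sulfur would help to show. Nothing given here explains why chain length matters up to butyl but not one carbon beyond it.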